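Changing the Ring on the Nitrogen of the Shared Core

A few compounds are considered here, and "the series" means these few. Any claim that something is new, unique, unknown or untested is made for them only; others in the source may bear on it.

Compound 1 `CC1(C)[C@H]2CC[C@]1(C)N(Cc1cn(-c3ccccc3F)nn1)C(=O)C2` gives 300 nM in a functional assay on SGC-7901 cells (Homo sapiens) for inhibition, read by MTT assay, with a stated time of 24 h; a lower number here means a stronger inhibitor, a higher number a weaker inhibitor.
Compound 2 `COc1ccccc1-n1cc(CN2C(=O)C[C@@H]3CC[C@@]2(C)C3(C)C)nn1` gives 280 nM in this assay.
Compound 3 `CC1(C)[C@H]2CC[C@]1(C)N(Cc1cn(-c3ccc(O)cc3)nn1)C(=O)C2` gives 330 nM in this assay.

The three measured compounds share one core and differ only in the ring carried on the aromatic nitrogen. Compound 2 holds a number that the other two match within the scatter: a 1.1-fold lower number from compound 1 to compound 2 (0.03 log units; within the scatter), and a 1.2-fold higher number from compound 2 to compound 3 (0.07 log units; within the scatter). The remaining pair behaves the same way, with a 1.1-fold higher number from compound 1 to compound 3 (0.04 log units; within the scatter).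

Compound 4 `CC1(C)[C@H]2CC[C@]1(C)N(Cc1cn(-c3ccc(Cl)cc3)nn1)C(=O)C2` is the next member of this set. Compared with compound 2, the change is 4-chlorophenyl in place of 2-methoxyphenyl on an aromatic nitrogen.

All three measured steps bear on this question, since each of them also swaps the ring on the aromatic nitrogen, and none of them moved the number beyond the scatter. A fluoro, a methoxy and a hydroxy on that ring gave numbers that cannot be told apart in this assay. On that basis the step to a chloro on the same ring is expected to show no change beyond the scatter either.

For compound 4 the estimate in this assay is therefore 300 nM, with a range from 150 nM to 600 nM, which means an expected step of a 1.1-fold higher number from compound 2 to compound 4 (0.03 log units; within the scatter).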

Compound 4, half-maximal inhibitory concentration: 410 nM
Compound 4: the middle estimate sits 1.4-fold (0.14 log units) below what was measured; the measured number falls inside the stated range.
By their numbers in this assay, from the lowest: compounds 2, 1, 3 and 4 (each within the scatter of the next).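

In this assay, the 4-chlorophenyl ring stays within the scatter of all three earlier rings (a 1.5-fold higher number from compound 2 to compound 4 (0.17 log units; within the scatter); a 1.2-fold higher number from compound 3 to compound 4 (0.09 log units; within the scatter); a 1.4-fold higher number from compound 1 to compound 4 (0.14 log units; within the scatter)). The new compound extends the tolerated set to a ring with 0 hydrogen-bond donors and 0 hydrogen-bond acceptors, whereas the 2-methoxyphenyl it replaces in compound 2 counts 1 hydrogen-bond acceptor, and this difference comes with no step beyond the scatter. Compound 3 and compound 4 also offer the cleanest single swap in the set, chloro in place of hydroxy on the same aromatic carbon, and nothing available explains why these numbers stay so close.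

Still open, on these data alone, is whether an amine or a carboxylic acid on this phenyl ring, a longer chain such as butoxy in place of methoxy, or a pyridine ring in place of the phenyl ring would also stay within the scatter. Equally open is how 2-chlorophenyl would compare with 4-chlorophenyl, as no pair shown keeps one group on the ring and moves it to another carbon.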